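This account rests on a few compounds, and the source may have more. Where it says the series, first, only, none or still open, it means among the compounds named here.

Among the compounds with values here, compound 1 `CC1=C(C(=O)OCCO[N+](=O)[O-])C(c2cccc3nonc23)C([N+](=O)[O-])=C(C)C1` gives 3890 nM in a functional assay (ileum) for antagonist activity, with Cavia porcellus as the target (a lower number here means a stronger inhibitor, a higher number a weaker inhibitor), the higher of the two numbers measured so far. Compound 2 `CC1=C(C(=O)OCCO[N+](=O)[O-])[C@@H](c2cccc3nonc23)C([N+](=O)[O-])=C(C)C1` gives 115 nM in this assay, and the step of a 34-fold lower number from compound 1 to compound 2 (1.53 log units; beyond the scatter) is the only measured one; it rests on the fact that one of compounds 1 and 2 is drawn with a defined configuration and the other without, at the place where they differ alone. Compound 3 `CC1=C(C(=O)OCCCO[N+](=O)[O-])C(c2cccc3nonc23)C([N+](=O)[O-])=C(C)C1` differs from compound 1 by (nitrooxy)methyl in place of nitrooxy on a saturated chain carbon, two bonds along the chain from an oxygen next to a carbonyl group. That single measured step concerns a stereocentre and does not bear on this chain change, so no step beyond the scatter is expected in this assay. Compound 3 is estimated at 3900 nM, between 1500 nM and 10000 nM, which expects a 1.0-fold higher number from compound 1 to compound 3 (0.00 log units; within the scatter).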

Compound 3, half-maximal inhibitory concentration: 241 nM
The estimate for compound 3 lay 16-fold (1.21 log units) above the measured number; the measured number lies below the stated range.
By their numbers in this assay, from the lowest: compound 2; then compound 3; then compound 1.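

Within the data shown here, replacing nitrooxy with (nitrooxy)methyl on a saturated chain carbon, two bonds along the chain from an oxygen next to a carbonyl group, gives a 16-fold lower number from compound 1 to compound 3 (1.21 log units; beyond the scatter) in this assay, so this chain, unchanged in the earlier compounds, is itself a place where the number moves. The stereocentre is drawn without a configuration in both compounds, so the step belongs to the chain change alone. Nothing at hand accounts for the size of this step.

On these data alone, whether a longer chain, such as 4-(nitrooxy)butoxy, lowers the number further remains open, as does whether a hydroxyl group or an amine could stand in place of the nitrooxy end. Also open, as far as these compounds go, is how the 3-(nitrooxy)propoxy chain behaves with the defined configuration of compound 2.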